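The compounds below may be only part of what the source reports. "The series", "measured", "known", "first", "only" and "open" are said of these compounds alone.

Working notes on the series, with everything read in a functional assay on DU-145 cells (Homo sapiens) for cytotoxicity, read by MTT assay, with a stated time of 48 h; a lower number here means a stronger inhibitor, a higher number a weaker inhibitor. Compound 1 (`COc1cc(/C=C2\C(=O)Nc3ccc(Cl)cc32)ccc1OCCCN1CCN(c2ccccn2)CC1`) gives > 20000 nM, which is a limit and not a number. The ceiling to keep in mind is the limit of > 20000 nM in this assay, at which 1 of the 2 values shown sits. Among the compounds with values here, compound 2 (`COc1cc(/C=C2\C(=O)Nc3ccc(Cl)cc32)ccc1OCCCN1CCN(c2ncccc2C(F)(F)F)CC1`) gives 1610 nM, the only actual number so far. Within the data shown here, the single measured step is an at least 12-fold lower number from compound 1 to compound 2 (1.09 log units; beyond the scatter), large and beyond the scatter.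

Compound 3 (`COc1cc(/C=C2\C(=O)Nc3ccc(Cl)cc32)ccc1OCCCN1CCN(C)CC1`) has not been measured. Its difference from compound 2 is methyl in place of 3-(trifluoromethyl)pyridin-2-yl on an amine nitrogen in a ring. The trifluoromethyl goes, and the aromatic ring goes with it. Among the measured compounds shown here, no measured step covers the loss of the whole group, so the guidance is only partial. For the measured compounds named here, a move to a higher number is expected, resting on an at least 12-fold lower number from compound 1 to compound 2 (1.09 log units; beyond the scatter), the one case where adding trifluoromethyl was the sole change. The expected step is a 4.3-fold higher number from compound 2 to compound 3 (0.64 log units; beyond the scatter), clearly beyond the scatter but poorly bounded. The estimate for compound 3 is 7000 nM, with an expected range of 2000 nM to 20000 nM.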

Compound 3, half-maximal inhibitory concentration: 2150 nM
Beside the measured number, compound 3's estimate is 3.3-fold (0.51 log units) above it; the range from low to high includes it.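

On the amine nitrogen in the ring, methyl and 3-(trifluoromethyl)pyridin-2-yl read alike in this assay, with a 1.3-fold higher number from compound 2 to compound 3 (0.13 log units; within the scatter), so at this position a measured value does not depend on keeping an aromatic ring or a trifluoromethyl. Within the data shown here, the group that stands apart is the pyridin-2-yl without trifluoromethyl, since methyl in its place gives an at least 9.3-fold lower number from compound 1 to compound 3 (0.96 log units; beyond the scatter), and the trifluoromethyl step therefore no longer reads as the only route away from compound 1. Compound 1 remains alone at the ceiling, and its value is a limit and not a number: the limit of > 20000 nM in this assay, at which 1 of the 3 values shown sits.

As far as these compounds go, the full size of both steps from compound 1 stays open, and so does the question of whether the pyridin-2-yl itself lowers the cytotoxicity or whether compound 1 is simply an isolated case among three compounds. From the compounds shown here alone, it is also open whether a hydrogen, an ethyl, a longer alkyl chain or a phenyl on this nitrogen reads with compound 2 and compound 3 or with compound 1, and whether a chlorine or a methyl in place of the trifluoromethyl on the pyridine does the same.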